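A New Amine Group on a Chain Carbon

This account rests on a few compounds, and the source may have more. Where it says the series, first, only, none or still open, it means among the compounds named here.

Measured in a functional assay on MCF7 cells (Homo sapiens) for inhibition, read by MTT assay, with a stated time of 48 h, tested at 10 uM; on this read-out lower numbers stand for less inhibition of growth and higher numbers for more inhibition of growth at the one concentration tested:
- compound 1 `Cc1cc(=O)c2c(O)cc(OCc3ccccc3Br)c([C@H]3CCN(C)C[C@H]3O)c2o1`: 45%
- compound 2 `CCN(CC)Cc1c(O)c([C@H]2CCN(C)C[C@H]2O)c2oc(C)cc(=O)c2c1O`: 24%
- compound 3 `Cc1cc(=O)c2c(O)c(CN3CCC(N4CCCCC4)CC3)c(O)c([C@H]3CCN(C)C[C@H]3O)c2o1`: 25%

The starting point is compound 2, which gives 24%. Its number and that of compound 3 lie within the usual scatter of repeated measurements, so these two cannot be told apart in this assay. Compound 1 gives a number beyond the scatter above that of compound 2, but it lacks the amine group that is changed here, so it offers little guidance.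

Compound 4 `Cc1cc(=O)c2c(O)c(CN3CCCC3C(=O)O)c(O)c([C@H]3CCN(C)C[C@H]3O)c2o1` has not yet been measured. It carries 2-carboxypyrrolidin-1-yl in place of diethylamino on a saturated chain carbon bound to an aromatic carbon.

For the measured compounds named here, no measured pair shows this exact replacement. The closest guide is compound 3, which also has a different group at this place and gives 25%, within the scatter of compound 2. On that evidence, no step beyond the scatter is expected, and the estimate is a number 4 percentage points lower from compound 2 to compound 4 (within the scatter). The new acid group adds uncertainty, so the expected range is kept wide. The estimated value for compound 4 is 20%, with an expected range from 7% to 35%.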

Compound 4, percent growth inhibition at one concentration: 21%
Estimate against measurement, compound 4: 1 percentage points below, within the range that was stated.
By their numbers in this assay, from the lowest: compounds 4, 2 and 3 (each within the scatter of the next); then compound 1.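

Replacing diethylamino with 2-carboxypyrrolidin-1-yl on a saturated chain carbon bound to an aromatic carbon gives, in this assay, a number 3 percentage points lower from compound 2 to compound 4 (within the scatter). For the compounds shown here, this is the first directly readable step at this place, and it shows that a larger group carrying both a five-membered ring and a carboxylic acid leaves compound 4 indistinguishable from compound 2 in this read-out. Nothing measured here explains why the two compounds cannot be told apart.

The compounds shown leave open what the ring and the carboxylic acid each contribute, and plain pyrrolidin-1-yl or the methyl ester of the acid on the same chain carbon would begin to separate the two parts. On these data alone, each compound is also represented by a reading at a single concentration, so it remains open whether compound 2 and compound 4 would still look alike at other concentrations.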